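Nitro for bromo on the aryl, with side chain held

This account rests on a few compounds, and the source may have more. Where it says the series, first, only, none or still open, it means among the compounds named here.

Two compounds have numbers in a functional assay on NCI-H460 cells (Homo sapiens) for cytotoxicity, read by MTT assay, with a stated time of 72 h; a higher number here means a weaker inhibitor, a lower number a stronger inhibitor. Compound 2 `COc1cc2c(Oc3ccc(NC(=O)c4nn(-c5ccc(Br)cc5)c(=O)c5ccccc45)cc3F)ccnc2cc1OCCCN1CCC(C)CC1` gives 350 nM, the lowest of the two. Going by the values given here, compound 1 `COc1cc2c(Oc3ccc(NC(=O)c4nn(-c5ccc([N+](=O)[O-])cc5)c(=O)c5ccccc45)cc3F)ccnc2cc1OCCCN1CCCC1` gives 1240 nM; it differs from compound 2 in two places, so no single step links them. Compound 3 `COc1cc2c(Oc3ccc(NC(=O)c4nn(-c5ccc([N+](=O)[O-])cc5)c(=O)c5ccccc45)cc3F)ccnc2cc1OCCCN1CCC(C)CC1` awaits measurement: nitro in place of bromo on an aromatic carbon. Compound 1, which also carries nitro, gives 1240 nM, a higher number. Compound 3 is therefore expected at 700 nM, with a range from 300 nM to 1700 nM. The expected step of a 2.0-fold higher number from compound 2 to compound 3 (0.30 log units; within the scatter) points toward a weaker inhibitor, with much uncertainty.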

Compound 3, half-maximal inhibitory concentration: 1340 nM
Beside the measured number, compound 3's estimate is 1.9-fold (0.28 log units) below it, and the stated range covers the measured number.
By their numbers in this assay, from the lowest: compound 2; then compounds 1 and 3 (each within the scatter of the next).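

With the side chain held, 4-nitrophenyl in place of 4-bromophenyl gives a 3.8-fold higher number from compound 2 to compound 3 (0.58 log units; beyond the scatter) in this assay. With nitro held, 4-methylpiperidin-1-yl in place of pyrrolidin-1-yl gives a 1.1-fold higher number from compound 1 to compound 3 (0.03 log units; within the scatter) and leaves the number within the scatter in this pair. No measurement at hand accounts for either step.

Open, as far as these compounds go, is whether the bromo-to-nitro step recurs with the pyrrolidin-1-yl side chain. Also open, from the compounds shown here alone, is where a 4-chlorophenyl, 4-methoxyphenyl or unsubstituted phenyl group would fall.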